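Adding Isopropyl to the Chain of Compound 2

A few compounds are considered here, and "the series" means these few. Any claim that something is new, unique, unknown or untested is made for them only; others in the source may bear on it.

- compound 1 `COc1cccc(/C=C/C(=O)N2Cc3ccccc3[C@@H](OCc3ccccc3)[C@@H]2CO)c1OC`: 39800 nM
- compound 2 `Cc1ccc(S(=O)(=O)NCC(=O)N2Cc3ccccc3[C@@H](OCc3ccccc3)[C@@H]2CO)cc1`: 6030 nM

In a functional assay on A549 cells (Homo sapiens) for antiproliferative activity, read by MTT assay, with a stated time of 48 h (a lower number here means a stronger inhibitor, a higher number a weaker inhibitor), compound 2 gives 6030 nM, the lower of the two numbers and so the stronger inhibitor of the pair. Compound 1 gives 39800 nM, and this gap lies beyond the usual scatter. The next compound, compound 3 `Cc1ccc(S(=O)(=O)N[C@H](C(=O)N2Cc3ccccc3[C@@H](OCc3ccccc3)[C@@H]2CO)C(C)C)cc1`, changes compound 2 at one place: isopropyl in place of hydrogen on a saturated chain carbon bound to a carbonyl carbon and a sulfonamide nitrogen. In words, this is isopropyl in place of hydrogen on a saturated chain carbon bound to a carbonyl carbon and a sulfonamide nitrogen. Among the measured compounds shown here, no measured pair shows what such a change does, so the only anchor is compound 2 at 6030 nM. With so little to go on, no step beyond the scatter is expected in this assay, and the expected step is a 1.2-fold lower number from compound 2 to compound 3 (0.08 log units; within the scatter). For compound 3, the estimated value is 5000 nM, with an expected range of 1500 nM to 20000 nM.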

Compound 3, half-maximal inhibitory concentration: 79400 nM
Compound 3: the middle estimate sits 16-fold (1.20 log units) below what was measured; the whole stated range lies below it.
By their numbers in this assay, from the lowest: compound 2; then compounds 1 and 3 (each within the scatter of the next).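

In this assay, this chain carbon proves far from indifferent: isopropyl in place of hydrogen gives a 13-fold higher number from compound 2 to compound 3 (1.12 log units; beyond the scatter) and so makes a much weaker inhibitor. Compound 1 and compound 2 differ in more than one place and could not isolate this position, whereas this single change shows that activity responds strongly to what sits on this carbon. No measurement shown here explains why the isopropyl group has this effect. From the compounds shown here alone, it remains open whether a smaller group such as methyl would keep the activity of compound 2 or already weaken it, so the size of group at which activity falls away is unknown. A chain carrying an amine or a carboxylic acid on this carbon is also untested among the compounds shown.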